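The compounds below may be only part of what the source reports. "The series", "measured", "known", "first", "only" and "open" are said of these compounds alone.

Measured in an ADME assay on J744 cells (Mus musculus) for cytotoxicity, read by MTT assay, with a stated time of 48 h; a lower number here means a stronger inhibitor, a higher number a weaker inhibitor:
- compound 1 `COc1cc(/C=N/NC(=O)c2no[n+]([O-])c2C)ccc1O`: > 400000 nM
- compound 2 `Cc1nc2ccccn2c1C(=O)N/N=C/c1ccc2no[n+]([O-])c2c1`: > 400000 nM
- compound 3 `COc1ccc(/C=N/NC(=O)c2no[n+]([O-])c2C)cc1OC`: > 400000 nM

Each of these entries is a limit of the assay and not a number.

Compound 3 stands at > 400000 nM, which is only a limit. The other two measured compounds also give only limits, so the set holds no numerical value, and the data show (the limit of > 400000 nM in this assay, at which 3 of the 3 values shown sit).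

Compound 4 `COc1ccc(/C=N/NC(=O)c2no[n+]([O-])c2C)cc1O` differs from compound 3 in one place: hydrogen in place of methyl on an oxygen on an aromatic ring. This is methoxy to hydroxy, hydrogen in place of methyl on an oxygen on an aromatic ring.

Going by the values given here, the only measured step of this kind runs the opposite way, a step that the two limits leave unreadable from compound 1 to compound 3, and it has no readable size. Given (the limit of > 400000 nM in this assay, at which 3 of the 3 values shown sit), no step beyond the scatter is expected in this assay, and a report of the same limit is the likeliest outcome. The estimated change is a number no higher from compound 3 to compound 4 (the limit leaves the size open). For compound 4 the estimate is 400000 nM, with an expected range from 150000 nM to 800000 nM.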

Compound 4, half-maximal inhibitory concentration: > 400000 nM
Compound 4: only a limit was reported (the forecaster's own chance of this, stated with the estimate: 75%); the middle value sits exactly at the limit.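

Compound 4 gives > 400000 nM in this assay, which is a limit and not a number. Compound 3 also gives only a limit, so no step can be read between compound 3 and compound 4. The compounds shown leave open whether any one-place change shifts this read-out: the limit of > 400000 nM in this assay, at which 4 of the 4 values shown sit.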